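Amide aryl swap near the ceiling of the read-out

A few compounds are considered here, and "the series" means these few. Any claim that something is new, unique, unknown or untested is made for them only; others in the source may bear on it.

Compound 1 `Cc1ccc(N2C(=O)C/C(=C\c3cccc(C(=O)Nc4cccc(F)c4)c3)C2=O)cc1` sits at the top of the two numbers available in an ADME assay on SW480 cells (Homo sapiens) for cytotoxicity, read by MTT assay, with a stated time of 72 h (on this read-out lower numbers stand for stronger inhibition and higher numbers for weaker inhibition), where compound 1 gives 96900 nM. Compound 3 `CCc1cccc(NC(=O)c2cccc(/C=C3\CC(=O)N(Cc4ccccc4)C3=O)c2)c1` gives 91500 nM in this assay, and the gap between the two stays within the scatter. Compound 2 `CCCCCN1C(=O)C/C(=C\c2cccc(C(=O)Nc3cccc(F)c3)c2)C1=O` reaches only the limit of the assay in this assay, at > 100000 nM. Among the compounds with values here, the single measured step, an at least 1.0-fold higher number from compound 1 to compound 2 (0.01 log units; that floor lies within the scatter), changes the group on the ring nitrogen rather than the amide aryl, and it runs into (the limit of > 100000 nM in this assay, at which 1 of the 3 values shown sits).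

Compound 4 `COc1ccc(NC(=O)c2cccc(/C=C3\CC(=O)N(c4ccc(C)cc4)C3=O)c2)cc1` differs from compound 1 on an amide-type nitrogen: 4-methoxyphenyl in place of 3-fluorophenyl on an amide-type nitrogen. Within the data shown here, no measured pair in the set alters that position, so no step can be carried over directly. All three values cluster at the upper end of the measurable range, and the two aryl amides compound 1 and compound 3 show no separation beyond the scatter. The expectation for compound 4 is therefore no step beyond the scatter, a 1.0-fold higher number from compound 1 to compound 4 (0.01 log units; within the scatter). Compound 4 is estimated at 100000 nM in this assay, with a range from 50000 nM to 200000 nM, and with a real chance that only the limit is reported.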

Compound 4, half-maximal inhibitory concentration: 93000 nM
For compound 4 the middle estimate is 1.1-fold (0.03 log units) above the measured one; the range from low to high includes it.
By their numbers in this assay, from the lowest: compounds 3, 4 and 1 (each within the scatter of the next). At a limit, above all of these: compound 2.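

The swap of 3-fluorophenyl for 4-methoxyphenyl on an amide-type nitrogen gives a 1.0-fold lower number from compound 1 to compound 4 (0.02 log units; within the scatter), the first step read at this position in this assay. With the 4-methylphenyl group on the ring nitrogen held constant, this exchange of one substituted aryl group for another, which also adds a hydrogen-bond acceptor to the count, leaves the read-out within the scatter, so this pair gives no sign that the read-out responds to the change. That finding carries little weight on its own, since the values of compound 1 and compound 4 lie close under the ceiling of the read-out, where little room remains to show a weakening: the limit of > 100000 nM in this assay, at which 1 of the 4 values shown sits.

Within the data shown here, only two aryl groups on this amide-type nitrogen can be compared with the rest of the molecule held constant, so it remains open whether a carboxylic acid or a dimethylamino group on that aryl ring, or a cyclohexyl group in its place, would move the number beyond the scatter. Going by these compounds, it is also open whether this position would respond in a compound whose value lies well away from the ceiling, as every compound shown sits near it.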